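Benzoxazinone to benzothiazolone on the triazole nitrogen

This account rests on a few compounds, and the source may have more. Where it says the series, first, only, none or still open, it means among the compounds named here.

Measured in a functional assay on HCT-116 cells (Homo sapiens) for inhibition, read by MTT assay, with a stated time of 72 h; on this read-out higher numbers stand for weaker inhibition of growth and lower numbers for stronger inhibition of growth:
compound 1 `COC1=C(OC)C(=O)C(CCCCCCCCCCn2cc(C[C@H](O)COCCOC[C@@H](O)Cc3ccc(-c4ccccc4)cc3)nn2)=C(C)C1=O`: 600 nM
compound 2 `O=C1COc2ccc(-n3cc(C[C@H](O)COCCOC[C@@H](O)Cc4ccc(-c5ccccc5)cc4)nn3)cc2N1`: 42500 nM
compound 3 `O[C@H](COCCOC[C@@H](O)Cc1cn(Cc2ccc(Oc3ccccc3)cc2)nn1)Cc1ccc(-c2ccccc2)cc1`: 3400 nM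

Compound 2 stands at the highest number of the three in this assay; compound 3 and compound 1 both sit at lower numbers, and both gaps lie beyond the usual scatter. Compound 4 `O=c1[nH]c2ccc(-n3cc(C[C@H](O)COCCOC[C@@H](O)Cc4ccc(-c5ccccc5)cc4)nn3)cc2s1` differs from compound 2 by a group of 10 heavy atoms (7 carbon, 1 nitrogen, 1 oxygen, 1 sulfur; one five-membered aromatic ring with 2 hetero atoms, one six-membered aromatic ring of carbon only) in place of a group of 11 heavy atoms (8 carbon, 1 nitrogen, 2 oxygen; one six-membered non-aromatic ring with 2 hetero atoms, one six-membered aromatic ring of carbon only), on an aromatic nitrogen. Within the data shown here, no pair of measured compounds isolates a change of this kind, so nothing fixes the size or the direction of the step. A small step, probably not beyond the scatter, is expected from compound 2 to compound 4 a 1.4-fold lower number from compound 2 to compound 4 (0.15 log units; within the scatter). On that basis compound 4 is estimated at 30000 nM, with a range from 8000 nM to 100000 nM.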

Compound 4, concentration for 50% growth inhibition: 9200 nM
Estimate against measurement, compound 4: 3.3-fold (0.51 log units) above; measured number inside the range.
By their numbers in this assay, from the lowest: compound 1; then compound 3; then compound 4; then compound 2.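

Swapping the group with the six-membered non-aromatic ring for the one with the five-membered aromatic ring gives a 4.6-fold lower number from compound 2 to compound 4 (0.66 log units; beyond the scatter) in this assay, the first step read at this position. The aromatic nitrogen therefore responds to a change that leaves the counts of hydrogen-bond donors and acceptors unchanged. No measurement at hand bears on the reason for this step.

The sulfur and the ring size change together, so their contributions stay unseparated. As far as these compounds go, whether an amine or a carboxylic acid on this group would move the number further remains open.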